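The compounds below may be only part of what the source reports. "The series", "measured", "known", "first", "only" and "open" are said of these compounds alone.

Measured so far in an assay on isolated protein for inhibition of ubiquitin carboxyl-terminal hydrolase 7 (Homo sapiens), with stated times of 30 min and 2 h; on this read-out higher numbers stand for weaker inhibition and lower numbers for stronger inhibition:
compound 1 `Cn1nc2c(=O)n(CC3(O)CCN(Cc4ccc(-c5cnco5)cc4Cl)CC3)cnc2c1-c1ccc(CN)cc1`: 71.6 nM
compound 2 `Cn1nc2c(=O)n(CC3(O)CCN(Cc4ccc(-c5cccs5)cc4Cl)CC3)cnc2c1-c1ccc(CN)cc1`: 38.6 nM

Among the compounds with values here, compound 2 stands at 38.6 nM in this assay, with compound 1 close beside it; the only measured step, a 1.9-fold lower number from compound 1 to compound 2 (0.27 log units; within the scatter), lies within the scatter, so the two are not separated by these numbers. Compound 3 `Cn1nc2c(=O)n(CC3(O)CCN(Cc4ccc(-c5ccco5)cc4Cl)CC3)cnc2c1-c1ccc(CN)cc1` differs from compound 2 by furan-2-yl in place of thiophen-2-yl on an aromatic carbon. Within the data shown here, the one step on record swaps one five-membered aromatic ring for another at this same position and shows no movement beyond the scatter; the change to compound 3 is of the same kind, a five-membered aromatic ring with 1 hetero atom giving way to another with 1 hetero atom, and no evidence supports a step beyond the scatter in either direction. Compound 3 is therefore expected to give about 45 nM in this assay, in a range from 20 nM to 100 nM. The expected step, a 1.2-fold higher number from compound 2 to compound 3 (0.07 log units; within the scatter), is estimated to stay within the scatter.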

Compound 3, half-maximal inhibitory concentration: 18.1 nM
For compound 3 the middle estimate is 2.5-fold (0.40 log units) above the measured one, and the stated range ends above it.
By their numbers in this assay, from the lowest: compound 3; then compounds 2 and 1 (each within the scatter of the next).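

In this assay, this position, on an aromatic carbon para to a large group, now separates two rings with the same counts, as furan-2-yl in place of thiophen-2-yl gives a 2.1-fold lower number from compound 2 to compound 3 (0.33 log units; beyond the scatter). Furan-2-yl in place of 1,3-oxazol-5-yl gives a 4.0-fold lower number from compound 1 to compound 3 (0.60 log units; beyond the scatter), which makes compound 3 the only compound separated from both others, while compound 1 and compound 2 stay unseparated. Nothing available accounts for the difference between these rings.

The compounds shown leave open whether a six-membered aromatic ring such as pyridin-3-yl, or a non-aromatic group such as morpholine or a carboxylic acid, can stand at this position. They also leave open whether furan-2-yl keeps its edge over thiophen-2-yl when the chloro group is replaced by fluoro or methyl.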